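Quaternary ammonium pyridone carboxamides: collagen promoter series

The source may report more compounds than this note shows. Statements on the series, on what has been measured and on what is new or still open speak of the compounds shown alone.

Measured compounds:
- compound 1 `Cc1cc(-n2cc(C(=O)Nc3cc(F)cc(F)c3)c(=O)c3ccc(N(C)C)nc32)ccc1OCCCCCCC[n+]1ccccc1`: 55%
- compound 2 `CN(C)c1ccc2c(=O)c(C(=O)Nc3cc(F)cc(F)c3)cn(-c3ccc(OCCCCCCC[n+]4ccccc4)c(Cl)c3)c2n1`: 21.4%
- compound 3 `Cc1cc(OCCCCCCC[N+](C)(C)C2CCCCC2)ccc1-n1cc(C(=O)Nc2cc(F)cc(F)c2)c(=O)c2ccc(N(C)C)nc21`: "not active" (no number reported)

In an assay on LX2 cells for inhibition of COL1A1 promoter (Homo sapiens), read by a luciferase reporter, with a stated time of 24 h, tested at 50 uM (a higher number here means a stronger effect of the compound at the concentration tested, a lower number a weaker effect), compound 1 gives 55%. Compound 2 carries the change (chloro in place of methyl on an aromatic carbon), and in this assay it gives 21.4%; the step of a number 33.6 percentage points lower from compound 1 to compound 2 (beyond the scatter) is large and beyond the scatter. Compound 3 differs from compound 1 in the charged end of the chain; the difference between the two cores is not broken down here. For compound 3 this assay reports no single number, only that it was found not active.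

Compound 4 `CN(C)c1ccc2c(=O)c(C(=O)Nc3cc(F)cc(F)c3)cn(-c3ccc(OCCCCCCC[N+](C)(C)C4CCCCC4)cc3Cl)c2n1` is not yet measured. It stands to compound 3 as compound 2 stands to compound 1: the change chloro in place of methyl on an aromatic carbon is the same one, at the same place. With compound 3 already without a measurable effect and the same change having cost compound 2 most of its effect relative to compound 1, a weak result is expected. The estimate for compound 4 in this assay is 10%, with a range from 0% to 30%, and a fair chance that only a limit is reported.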

Compound 4, a percentage reported as inhibition, at one concentration (the size of the read-out at that concentration, not a potency): "not active" (no number reported)
Nothing numeric was reported for compound 4; no gap can be computed for the estimate.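

In this assay compound 3 gives "not active" (no number reported) and compound 4 gives "not active" (no number reported), so no step can be read between these two compounds. No supporting data bear on this result. Still open, going by these compounds, is whether chloro in place of methyl changes the effect at all when the chain carries the charged end of compound 3.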